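Nitro Enters the Phenyl of Compound 3

This account rests on a few compounds, and the source may have more. Where it says the series, first, only, none or still open, it means among the compounds named here.

Compound 1, `Nc1sc(-c2ccccc2)c(-c2cccc(C(F)(F)F)c2)c1C(=O)c1ccccc1`: in an assay on CHO-K1 cells for displacement of a labelled ligand from adenosine receptor A1 (Homo sapiens), tested at 10 uM (a lower number here means less inhibition, a higher number more inhibition at the concentration tested (going by the name of the read-out)), compound 1 gives 82.4%.
Compound 2, `COc1ccc(-c2sc(N)c(C(=O)c3ccccc3)c2-c2cccc(C(F)(F)F)c2)cc1`: in this assay compound 2 gives 65.2%.
Compound 3, `CCOC(=O)c1c(N)sc(-c2ccccc2)c1-c1cccc(C(F)(F)F)c1`: in this assay compound 3 gives 83.6%.

Compound 3 stands highest of the three numbers, but its step from compound 1, a number 1.2 percentage points higher from compound 1 to compound 3 (within the scatter), lies within the scatter; only compound 2 sits clearly lower. Compound 4, `CCOC(=O)c1c(N)sc(-c2ccc([N+](=O)[O-])cc2)c1-c1cccc(C(F)(F)F)c1`, differs from compound 3 by nitro in place of hydrogen on an aromatic carbon. For the measured compounds named here, one measured step bears on this: a number 17.2 percentage points lower from compound 1 to compound 2 (beyond the scatter), a modest loss when methoxy replaced hydrogen on the same phenyl. Nitro is a different group and no other step on this ring has been measured, so the expectation rests on that single comparison. Compound 4 is therefore expected to show a modest fall, a number 13.6 percentage points lower from compound 3 to compound 4 (beyond the scatter), in this assay. Compound 4 is estimated at 70%, within a range from 50% to 88%.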

Compound 4, a percentage reported as inhibition, at one concentration (the size of the read-out at that concentration, not a potency): 71.4%
Estimate against measurement, compound 4: 1.4 percentage points below; low and high end bracket the measured number.
By their numbers in this assay, from the lowest: compounds 2 and 4 (each within the scatter of the next); then compounds 1 and 3 (each within the scatter of the next).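

In this assay, nitro in place of hydrogen gives a number 12.2 percentage points lower from compound 3 to compound 4 (beyond the scatter), so a fall at this phenyl no longer rests on methoxy alone, which gave a number 17.2 percentage points lower from compound 1 to compound 2 (beyond the scatter). The fall also now appears with ethoxy rather than phenyl on the carbonyl. Nothing measured here explains either step.

As far as these compounds go, whether an amine or a chlorine in the same place would also lower the number remains open. So does whether methoxy and nitro would each give a step of similar size on one shared core.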